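This account rests on a few compounds, and the source may have more. Where it says the series, first, only, none or still open, it means among the compounds named here.

In an ADME assay on MT2 cells (Homo sapiens) for cytotoxicity (a lower number here means that less compound is tolerated, a higher number that more compound is tolerated), compound 2 `CC(C)=CCOc1cc(Nc2ncccn2)ccc1Cl` gives 2500 nM, and compound 1 `COc1ccnc(Nc2ccc(Cl)c(OCC=C(C)C)c2)n1` gives 9000 nM. The change between them, (methoxy in place of hydrogen on an aromatic carbon), made the step of a 3.6-fold higher number from compound 2 to compound 1 (0.56 log units; beyond the scatter). Compound 3 `COc1ccnc(Nc2ccc(C#N)c(OCC=C(C)C)c2)n1` carries a different core; the difference between the cores of compound 3 and compound 2 is not broken down here. In this assay compound 3 gives 230 nM, the lowest of the three numbers, and the step of a 39-fold lower number from compound 1 to compound 3 (1.59 log units; beyond the scatter) is the largest seen.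

Compound 4 `COc1cc(OC)nc(Nc2ccc(C#N)c(OCC=C(C)C)c2)n1` has not yet been measured in this assay. It differs from compound 3 by methoxy in place of hydrogen on an aromatic carbon. This is the same kind of change as from compound 2 to compound 1, but not the same: in compound 4 the entering group is also meta to a methoxy group (2 heavy atoms), which was not so in compound 1. Among the compounds with values here, the earlier step of a 3.6-fold higher number from compound 2 to compound 1 (0.56 log units; beyond the scatter) is the only guide. The author expects compound 4 to stand at 600 nM, estimated between 200 nM and 1800 nM, because compound 3 gives 230 nM and the expected step is a 2.6-fold higher number from compound 3 to compound 4 (0.42 log units; beyond the scatter).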

Compound 4, half-maximal cytotoxic concentration: 810 nM
Beside the measured number, compound 4's estimate is 1.4-fold (0.13 log units) below it; the measured number falls inside the stated range.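

In this assay, methoxy in place of hydrogen on an aromatic carbon gave a 3.5-fold higher number from compound 3 to compound 4 (0.55 log units; beyond the scatter), and this step can be set directly against the earlier one on the chloro-bearing core. Within this pair of cores, the change carried across with no difference in size, even though in compound 4 the entering group is also meta to a methoxy group, which was not so in compound 1: the same change on two cores in this assay, a 3.6-fold higher number (0.56 log units; beyond the scatter) from compound 2 to compound 1 and a 3.5-fold higher number (0.55 log units; beyond the scatter) from compound 3 to compound 4, 1.0-fold (0.01 log units) apart, within the scatter of two such steps This rests on only two steps, so it does not show that the size would hold on any further core, and it does not explain why the number rises or why the two steps match.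

The compounds shown leave open whether an ethoxy group, a longer chain or an amine in place of the methoxy would give a step of similar size. Also open, from the compounds shown here alone, is whether a second methoxy group on the core of compound 1 would repeat the step seen from compound 3 to compound 4.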